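The compounds below may be only part of what the source reports. "The series", "measured", "known", "first", "only" and "open" are said of these compounds alone.

In a functional assay on HeLa cells (Homo sapiens) for cytotoxicity, read by MTT assay, with a stated time of 72 h (a lower number here means a stronger inhibitor, a higher number a weaker inhibitor), compound 1 `O=c1c(CSc2cc(=O)c3ccccc3s2)coc2ccccc12` gives 2600 nM. Compound 2 `Cc1nnc(Sc2coc3ccccc3c2=O)s1` gives only a limit, > 50000 nM, in this assay, which is the limit of > 50000 nM in this assay, at which 1 of the 3 values shown sits. Compound 3 `Cc1nnc(SCc2coc3ccc(Cl)cc3c2=O)o1`, which carries a chloro substituent on its core and a methylene between the thioether sulfur and the five-membered ring, gives 3200 nM in this assay. Among the numbers that exist, compound 3 sits alongside compound 1, the gap between the two being within the usual scatter; the third value is a limit and not a number.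

Compound 4 `Cc1nnc(SCc2coc3ccc(Cl)cc3c2=O)s1` differs from compound 3 in one place: 5-methyl-1,3,4-thiadiazol-2-yl in place of 5-methyl-1,3,4-oxadiazol-2-yl on a sulfur. Within the data shown here, no measured pair shows this exchange on its own, and compound 2, which also carries the thiadiazole, differs from compound 4 in more than one place, so its limit gives no direct guide. The step from compound 3 to compound 4 in this assay is expected to be small, most likely within the scatter, with no firm direction. Compound 4 is therefore estimated at 3500 nM, within a range of 1200 nM to 12000 nM, which means an expected step of a 1.1-fold higher number from compound 3 to compound 4 (0.04 log units; within the scatter).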

Compound 4, half-maximal inhibitory concentration: 9700 nM
Estimate against measurement, compound 4: 2.8-fold (0.44 log units) below; measured number inside the range.
By their numbers in this assay, from the lowest: compounds 1 and 3 (each within the scatter of the next); then compound 4. At a limit, above all of these: compound 2.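

In this assay, putting 5-methyl-1,3,4-thiadiazol-2-yl in place of 5-methyl-1,3,4-oxadiazol-2-yl on a sulfur whose other neighbour is a saturated chain carbon gives a 3.0-fold higher number from compound 3 to compound 4 (0.48 log units; beyond the scatter). This is the only step shown between compounds that differ in one place, and it establishes that the read-out responds to the identity of this five-membered ring, even though the exchange swaps only one ring atom and leaves the counted donors and acceptors unchanged. No measurement shown accounts for this step.

As far as these compounds go, the step rests on a single pair, and whether the same exchange moves the number in the same direction on another core remains open. Also open, from the compounds shown here alone, is how a phenyl ring or a simple amine would stand on this sulfur.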